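The source may report more compounds than this note shows. Statements on the series, on what has been measured and on what is new or still open speak of the compounds shown alone.

In this assay, an assay on isolated protein for inhibition of thyroid hormone receptor alpha (Homo sapiens), read by fluorescence polarization (on this read-out lower numbers stand for stronger inhibition and higher numbers for weaker inhibition), compound 1, `CS(=O)(=O)c1ccc(C(=O)NCC(=O)N(Cc2ccccc2)Cc2ccccc2)cc1[N+](=O)[O-]`, gives 1700 nM. Compound 2, `CN(Cc1cccc(F)c1)C(=O)CNC(=O)c1ccc(S(C)(=O)=O)c([N+](=O)[O-])c1`, returns only a limit of the assay, > 60000 nM, not a number. Compound 3, `CN1CCN(C(=O)CNC(=O)c2ccc(S(C)(=O)=O)c([N+](=O)[O-])c2)CC1`, also returns only a limit in this assay, > 60000 nM, so on the numbers shown it stands at the limit of > 60000 nM in this assay, at which 2 of the 3 values shown sit, rather than at a measured value. Compound 4, `CN(Cc1ccccc1)C(=O)CNC(=O)c1ccc(S(C)(=O)=O)c([N+](=O)[O-])c1`, differs from compound 3 by benzyl(methyl)amino in place of 4-methylpiperazin-1-yl on a carbonyl carbon. Compound 2 likewise sits only at a limit in this assay. Going by the values given here, with no step between measured compounds available, the expected step from compound 3 to compound 4 is toward stronger inhibition, likely beyond the scatter but modest, given that compound 1 gives 1700 nM. Compound 4 is therefore estimated at 35000 nM, between 7000 nM and 150000 nM, a change of an at least 1.7-fold lower number from compound 3 to compound 4 (0.23 log units; that floor lies within the scatter) expected.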

Compound 4, half-maximal inhibitory concentration: > 60000 nM
Compound 4 gave a limit, no number; the forecaster's own chance of this, stated with the estimate: 50%; at least 1.7-fold (0.23 log units) between middle value and limit.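

In this assay, hydrogen in place of phenyl on a saturated chain carbon bound to an amide-type nitrogen gives an at least 35-fold higher number from compound 1 to compound 4 (1.54 log units; beyond the scatter), so the phenyl of compound 1 carries a large part of its measured inhibition. Compound 4 is itself only a limit of the assay: the limit of > 60000 nM in this assay, at which 3 of the 4 values shown sit. The steps to compound 4 from compound 2 and from compound 3 cannot be read, since both ends are limits. As far as these compounds go, what remains open is how far compound 2, compound 3 and compound 4 differ from one another. From the compounds shown here alone, it is also open whether a cyclohexyl or pyridyl ring could stand in for that phenyl.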